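Swapping the outer ring of a fatty acid receptor agonist

The source may hold more compounds than are shown below. What is called first, only, known or untested is meant among the compounds shown, and "the series" means these compounds.

Compound 1 `CCc1ccccc1-c1cccc(COc2ccc([C@H](CC(=O)O)c3nccn3C)cc2)c1`: 48 nM
Compound 2 `Cn1ccnc1[C@@H](CC(=O)O)c1ccc(OCc2cccc(-c3ccccc3Cl)c2)cc1`: 43 nM

Both compounds share the same acid-bearing core and differ only in the group on the outer aromatic ring. In an assay on CHO cells for agonist activity at Free fatty acid receptor 1 (Homo sapiens), read by luminescence, with a stated time of 20 s, in the presence of a further agent that is not named here (a lower number here means that less compound is needed, a higher number that more compound is needed for the effect), compound 1 gives 48 nM and compound 2 gives 43 nM. For the measured compounds named here, the single step between them, a 1.1-fold lower number from compound 1 to compound 2 (0.05 log units; within the scatter), shows that exchanging chloro for ethyl at that position changed nothing that the assay can resolve. Compound 2 therefore stands at the lower of the two numbers, but only within the scatter of compound 1.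

Compound 3 `COc1ccc(-c2cccc(COc3ccc([C@H](CC(=O)O)c4nccn4C)cc3)c2)cc1` carries 4-methoxyphenyl in place of 2-chlorophenyl on an aromatic carbon. Going by the values given here, this change is larger than the one between compound 1 and compound 2: not only does the substituent change from chlorine to methoxy, its position on the outer ring moves, as the names 2-chlorophenyl and 4-methoxyphenyl indicate. Among the compounds with values here, no measured step covers such a move, so the one step known, a 1.1-fold lower number from compound 1 to compound 2 (0.05 log units; within the scatter), bears on it only loosely. A modest loss seems the more likely outcome in this assay, expected as a 2.8-fold higher number from compound 2 to compound 3 (0.45 log units; beyond the scatter). Compound 3 is estimated at 120 nM, with a range from 40 nM to 400 nM.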

Compound 3, half-maximal effective concentration: 440 nM
Compound 3: the middle estimate sits 3.7-fold (0.56 log units) below what was measured; measured number above the stated range.
By their numbers in this assay, from the lowest: compounds 2 and 1 (each within the scatter of the next); then compound 3.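

Here the outer ring proves not to be freely exchangeable at this place, on an aromatic carbon meta to a large group. In this assay, 4-methoxyphenyl in place of 2-chlorophenyl gives a large loss (a 10-fold higher number from compound 2 to compound 3 (1.01 log units; beyond the scatter)), and 4-methoxyphenyl in place of 2-ethylphenyl gives a similar loss (a 9.2-fold higher number from compound 1 to compound 3 (0.96 log units; beyond the scatter)), so the indifference seen between chloro and ethyl does not extend to every substituted phenyl ring at this place. Nothing available here explains why the number rises so far.

The swap alters two things at once, the substituent and where it sits on the outer ring, since the 2- in the earlier names becomes a 4- in the new one, and the compounds shown cannot tell which of the two accounts for the loss. A 2-methoxyphenyl group would keep the earlier placement with the new substituent, and a 4-chlorophenyl group would keep the earlier substituent in the new placement, so this pair would separate the two effects.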